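Pyridine nitrogen on the imidazole-borne phenyl ring

The source may hold more compounds than are shown below. What is called first, only, known or untested is meant among the compounds shown, and "the series" means these compounds.

Compound 2 `c1ccc(-c2ncc(-c3cnc(-c4ccccc4)[nH]3)cn2)cc1`: 8.88 nM
Compound 1 `c1ccc(-c2ncc(-c3cnc(-c4ccccn4)nc3)[nH]2)cc1`: 1770 nM

In an assay on isolated protein for inhibition of Hematopoietic prostaglandin D synthase (Homo sapiens), read by fluorescence polarization (a higher number here means a weaker inhibitor, a lower number a stronger inhibitor), compound 2 gives the lower of the two numbers, with compound 1 a step away: a 200-fold lower number from compound 1 to compound 2 (2.30 log units; beyond the scatter). Compound 3 `c1ccc(-c2ncc(-c3cnc(-c4cccnc4)[nH]3)cn2)cc1` is compound 2 with pyridin-3-yl in place of phenyl on an aromatic carbon. For the measured compounds named here, the only measured step swapped a ring nitrogen in and out on the other aromatic ring, and it was large, so adding a ring nitrogen is expected to weaken binding, though at this different position a smaller step is estimated: a 3.4-fold higher number from compound 2 to compound 3 (0.53 log units; beyond the scatter). For compound 3 the estimate in this assay is 30 nM, between 7 nM and 150 nM.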

Compound 3, half-maximal inhibitory concentration: 13.2 nM
Compound 3: middle estimate off by 2.3-fold (0.36 log units), on the high side; the range from low to high includes it.
By their numbers in this assay, from the lowest: compounds 2 and 3 (each within the scatter of the next); then compound 1.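

In this assay, putting pyridin-3-yl in place of phenyl on the aromatic carbon between two ring nitrogen atoms gives a 1.5-fold higher number from compound 2 to compound 3 (0.17 log units; within the scatter), so the two compounds cannot be told apart. A ring nitrogen in this ring therefore leaves the number within the scatter, whereas the change on the other ring was large, at a 200-fold lower number from compound 1 to compound 2 (2.30 log units; beyond the scatter). Nothing available explains this contrast between the two places. Still open, going by these compounds, is whether a pyridin-4-yl ring, or a phenyl ring carrying an amine or a carboxylic acid, would fit here equally well.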